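The source may report more compounds than this note shows. Statements on the series, on what has been measured and on what is new or still open speak of the compounds shown alone.

In a functional assay on MGC-803 cells (Homo sapiens) for inhibition, read by sulforhodamine B assay (on this read-out lower numbers stand for stronger inhibition and higher numbers for weaker inhibition), compound 1 (`O=C1C(Nc2ccccc2F)=CC(=O)c2c1nc1n2[C@H]2OC[C@@H](O)[C@H]2OC1`) gives 2000 nM and compound 2 (`O=C1C(Nc2ccc(Br)cc2)=CC(=O)c2c1nc1n2[C@H]2OC[C@@H](O)[C@H]2OC1`) gives 2020 nM while compound 3 (`Cc1ccc(NC2=CC(=O)c3c(nc4n3[C@H]3OC[C@@H](O)[C@H]3OC4)C2=O)cc1`) gives 1550 nM as its value. Compound 3 thus stands level with both others, within the scatter. Compound 4 (`O=C1C(N2CCCCC2)=CC(=O)c2c1nc1n2[C@H]2OC[C@@H](O)[C@H]2OC1`) has piperidin-1-yl in place of (4-methylphenyl)amino on a double-bonded ring carbon. The nearest evidence is a 1.3-fold lower number from compound 1 to compound 3 (0.11 log units; within the scatter) and a 1.3-fold lower number from compound 2 to compound 3 (0.12 log units; within the scatter) which stay within the scatter, as does a 1.0-fold higher number from compound 1 to compound 2 (0.00 log units; within the scatter) among the others. These steps only exchange groups on the phenyl ring, so none tests the loss of that ring or of the hydrogen-bond donor. A small, tentative rise is therefore expected in this assay as an estimated 1.6-fold higher number from compound 3 to compound 4 (0.21 log units; within the scatter) in size. For compound 4 the estimate is 2500 nM with an expected range of 800 nM to 8000 nM overall.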

Compound 4, half-maximal inhibitory concentration: > 4000 nM
Compound 4: only a limit was reported; the forecaster's own chance of this, stated with the estimate: 5%; middle value at least 1.6-fold (0.20 log units) away from the limit.
By their numbers in this assay, from the lowest: compounds 3, 1 and 2 (each within the scatter of the next). At a limit, above all of these: compound 4.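

In this assay, for the compounds shown here, piperidin-1-yl on the double-bonded ring carbon gives the first step here that lies beyond the scatter: an at least 2.5-fold higher number from compound 3 to compound 4 (0.41 log units; beyond the scatter). Against the other two groups, the floors lie within the scatter: an at least 1.9-fold higher number from compound 2 to compound 4 (0.29 log units; that floor lies within the scatter) and an at least 2.0-fold higher number from compound 1 to compound 4 (0.30 log units; that floor lies within the scatter). The value of compound 4 is a limit, not a number: the limit of > 4000 nM in this assay, at which 1 of the 4 values shown sits.

This change removes the aromatic ring and the hydrogen-bond donor together, so the compounds shown cannot separate the two. A cyclohexylamino group would keep the donor without the aromatic ring, and a methyl(phenyl)amino group would keep the aromatic ring without the donor.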